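The source may report more compounds than this note shows. Statements on the series, on what has been measured and on what is new or still open speak of the compounds shown alone.

Measured so far:
- compound 1, `CC1(C)C(=O)N(C2CCCCC2)c2nc(Nc3cccc(N4CCNCC4)c3)ncc21`: 14 nM
- compound 2, `CC1(C)C(=O)N(c2ccccc2)c2nc(Nc3ccccc3)ncc21`: 2800 nM

Compound 1 gives 14 nM in an assay on isolated protein for inhibition of MAP/microtubule affinity-regulating kinase 3 (Homo sapiens), read by HTRF (on this read-out lower numbers stand for stronger inhibition and higher numbers for weaker inhibition), the lower of the two numbers recorded; compound 2 gives 2800 nM, a much higher number, beyond the usual scatter of this assay. For the measured compounds named here, the two compounds differ in more than one place, so their two values are simply taken as they stand and no single step is drawn between them.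

Compound 3, `CN1C(=O)C(C)(C)c2cnc(Nc3cccc(N4CCNCC4)c3)nc21`, has not yet been measured in this assay. It is made from compound 1 by one change: methyl in place of cyclohexyl on an amide-type nitrogen in a ring. Going by the values given here, no step of this kind between measured compounds is available, so the expectation rests on compound 1 alone and on the nature of the change. The expected step from compound 1 to compound 3, estimated as a 4.3-fold higher number from compound 1 to compound 3 (0.63 log units; beyond the scatter), points toward a higher number, a loss that is expected to lie somewhat beyond the scatter, though with wide uncertainty. Compound 3 is accordingly estimated at 60 nM in this assay, with a range from 15 nM to 300 nM.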

Compound 3, half-maximal inhibitory concentration: 850 nM
The estimate for compound 3 lay 14-fold (1.15 log units) below the measured number, outside the stated range (above it).
By their numbers in this assay, from the lowest: compound 1; then compound 3; then compound 2.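

Within this assay, the group on the amide-type nitrogen in a ring turns out to carry much of the inhibition seen with compound 1: with the rest of the structure unchanged, methyl in place of cyclohexyl gives a 61-fold higher number from compound 1 to compound 3 (1.78 log units; beyond the scatter) as a large step, well beyond the scatter. The earlier pair could not show this, as compound 1 and compound 2 differ in more than one place and no single change could be read from them, whereas here one substitution, from a cyclohexyl of 6 heavy atoms to a methyl of 1 heavy atom, is isolated at this position. Nothing at hand bears on what lies behind this step.

On these data alone, it remains open whether the ring of cyclohexyl is what counts or whether an open chain such as isopropyl or n-butyl, or a smaller ring such as cyclopentyl, would hold the number close to that of compound 1. The contribution of phenyl on this nitrogen also stays unresolved, as it occurs only in compound 2, which differs from compound 1 in a second place as well.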